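The source may report more compounds than this note shows. Statements on the series, on what has been measured and on what is new or still open speak of the compounds shown alone.

Compounds measured so far:
- compound 1 `c1ccc(-c2cnccn2)c(OCC2=NCCN2)c1`: 97%
- compound 2 `Cc1ccc(-c2ccccc2OCC2=NCCN2)s1`: 97%
- compound 3 `Cc1csc(-c2ccccc2OCC2=NCCN2)n1`: 104%

In a functional assay with Alpha-1A adrenergic receptor (Homo sapiens) as the target, read by calcium flux (on this read-out higher numbers stand for larger maximal responses and lower numbers for smaller maximal responses), compound 1 gives 97%. It stands level with compound 2 at the digits shown, and together these two are the lowest of the three numbers; the nearest neighbour is compound 2, with no change at the digits printed from compound 1 to compound 2 (within the scatter), and the furthest is compound 3, with a number 7 percentage points higher from compound 1 to compound 3 (within the scatter). The step to compound 4 `Cc1cnsc1-c1ccccc1OCC1=NCCN1` changes the same part of the shared core as these steps: 4-methyl-1,2-thiazol-5-yl in place of pyrazin-2-yl on an aromatic carbon.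

Going by the values given here, two measured steps bear on this change. Swapping pyrazin-2-yl for 5-methylthiophen-2-yl gave no change at the digits printed from compound 1 to compound 2 (within the scatter), and swapping it for 4-methyl-1,3-thiazol-2-yl gave a number 7 percentage points higher from compound 1 to compound 3 (within the scatter); between those two five-membered rings the step of a number 7 percentage points higher from compound 2 to compound 3 (within the scatter) was likewise within the scatter. The maximal response therefore looks insensitive to which ring sits at this carbon, so for compound 4 a step of a number 3 percentage points higher from compound 1 to compound 4 (within the scatter) is expected, none beyond the scatter. Compound 4 is estimated to give 100%, expected between 88% and 112%.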

Compound 4, largest response reached (reported as maximum), in percent of the reference or control that the assay uses: 104%
Estimate against measurement, compound 4: 4 percentage points below; the range from low to high includes it.
By their numbers in this assay, from the lowest: compounds 1, 2, 3 and 4 (each within the scatter of the next).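

In this assay the 4-methyl-1,2-thiazol-5-yl group is a third five-membered aromatic ring at this carbon, and it also stays within the scatter of the other groups, with a number 7 percentage points higher from compound 1 to compound 4 (within the scatter) and a number 7 percentage points higher from compound 2 to compound 4 (within the scatter). The closest comparison is with the other methylthiazolyl group, where the result was no change at the digits printed from compound 3 to compound 4 (within the scatter), so on this read-out the two cannot be told apart. No measurement at hand accounts for this flat picture.

Going by these compounds, all four groups at this carbon are aromatic rings, so it remains open whether the maximal response would hold with an open-chain amine or a carboxylic acid there. The maximal response alone also leaves open how these compounds compare in the concentration needed to reach it.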